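Adding a methoxy to the free amine compound

This account rests on a few compounds, and the source may have more. Where it says the series, first, only, none or still open, it means among the compounds named here.

Measured in a functional assay on MOLT-4 cells (Homo sapiens) for antiproliferative activity, with a stated time of 48 h; a higher number here means a weaker inhibitor, a lower number a stronger inhibitor:
- compound 1 `C=C(Br)C(=O)Nc1ccc(/C=C/C(=O)c2ccccc2)cc1` gives 3100 nM
- compound 2 `C=C(Br)C(=O)Nc1ccc(/C=C/C(=O)c2cccc(OC)c2)cc1` gives 850 nM
- compound 3 `Nc1ccc(/C=C/C(=O)c2ccccc2)cc1` gives 10000 nM

Among these three, a higher number marks a weaker inhibitor, and compound 3 has the highest number. Its closest neighbour is compound 1, which carries a (1-bromoethenyl)carbonyl on the nitrogen where compound 3 has a hydrogen. That change gives a 3.2-fold higher number from compound 1 to compound 3 (0.51 log units; beyond the scatter).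

The next compound, compound 4 `COc1cccc(C(=O)/C=C/c2ccc(N)cc2)c1`, keeps the core of compound 3 and changes it in one place: methoxy in place of hydrogen on an aromatic carbon. The methoxy takes the place of a hydrogen on an aromatic carbon, meta to a large group.

The same replacement has been measured once, and it gave a 3.6-fold lower number from compound 1 to compound 2 (0.56 log units; beyond the scatter). That step is modest, and it was seen with the (1-bromoethenyl)carbonyl group present, which compound 3 lacks. Within the data shown here, one example cannot show whether the effect carries over, but it is the only direct guide. A step of similar size towards a lower number is therefore expected in this assay. The expected change is a 3.6-fold lower number from compound 3 to compound 4 (0.55 log units; beyond the scatter). For compound 4 the estimated value is 2800 nM, with an expected range from 1000 nM to 7500 nM.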

Compound 4, half-maximal inhibitory concentration: 20000 nM
Estimate against measurement, compound 4: 7.1-fold (0.85 log units) below; measured number above the stated range.
By their numbers in this assay, from the lowest: compound 2; then compound 1; then compounds 3 and 4 (each within the scatter of the next).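

In this assay methoxy in place of hydrogen on this aromatic carbon gives no step beyond the scatter when the nitrogen carries only hydrogen, with a 2.0-fold higher number from compound 3 to compound 4 (0.30 log units; within the scatter). The gain seen with the (1-bromoethenyl)carbonyl group present therefore does not carry over to the free amine, and the outcome of this one change depends on the core that receives it: the same change on two cores in this assay, a 3.6-fold lower number (0.56 log units; beyond the scatter) from compound 1 to compound 2 and a 2.0-fold higher number (0.30 log units; within the scatter) from compound 3 to compound 4, 7.3-fold (0.86 log units) apart, beyond the scatter of two such steps.

Read from the other direction, the (1-bromoethenyl)carbonyl group matters far more where the methoxy is present, with a 24-fold higher number from compound 2 to compound 4 (1.37 log units; beyond the scatter), so the two changes do not simply add up: the same change on two cores in this assay, a 3.2-fold higher number (0.51 log units; beyond the scatter) from compound 1 to compound 3 and a 24-fold higher number (1.37 log units; beyond the scatter) from compound 2 to compound 4, 7.3-fold (0.86 log units) apart, beyond the scatter of two such steps.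

Going by these compounds, how a hydroxyl, a fluorine or an ethoxy on this aromatic carbon would behave on either core stays open, since a single group at a single place cannot separate what is special to methoxy from what is general to this carbon. Also open, on these data alone, is whether the link between the two sites holds for another group on the nitrogen, such as a plain acetyl or a propenoyl without the bromine.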